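Compound 1 and its 2-methyl-1H-indol-3-yl counterpart, compound 4

The source may report more compounds than this note shows. Statements on the series, on what has been measured and on what is new or still open speak of the compounds shown alone.

In a functional assay on HCT-116 cells (Homo sapiens) for antiproliferative activity, with a stated time of 72 h (a higher number here means a weaker inhibitor, a lower number a stronger inhibitor), compound 1 `O=C(COc1ccc(CNC2CC=C(c3c[nH]c4cccc(F)c34)CC2)c(F)c1)NO` gives 173 nM, the lowest number among the three compounds measured. In this assay compound 3 `Cc1[nH]c2ccccc2c1C1=CCN(Cc2ccc(OCC(=O)NO)cc2F)CC1` gives 1220 nM, a clearly higher number than that of compound 1. Compound 2 `O=C(COc1ccc(CN2CC=C(c3c[nH]c4ccc(F)cc34)CC2)c(F)c1)NO` gives > 5000 nM in this assay, which is a limit and not a number.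

Compound 4 `Cc1[nH]c2ccccc2c1C1=CCC(NCc2ccc(OCC(=O)NO)cc2F)CC1` keeps the core of compound 1 and changes one group: 2-methyl-1H-indol-3-yl in place of 4-fluoro-1H-indol-3-yl on a double-bonded ring carbon. Within the data shown here, one measured step bears on this change: an at least 4.0-fold lower number from compound 2 to compound 3 (0.61 log units; beyond the scatter), where 2-methyl-1H-indol-3-yl takes the place of 5-fluoro-1H-indol-3-yl. That step favours the 2-methyl-1H-indol-3-yl group, but it is only an indirect guide. It starts from a limit, it sits on a different core from that of compound 1, and the group it removes is not 4-fluoro-1H-indol-3-yl. No measurement compares the 4-fluoro-1H-indol-3-yl and 2-methyl-1H-indol-3-yl groups directly, so no firm direction can be drawn. The expected size is a 1.2-fold higher number from compound 1 to compound 4 (0.06 log units; within the scatter) and so none beyond the scatter. Compound 4 is estimated at 200 nM in this assay, with an expected range from 60 nM to 700 nM for its measurements.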

Compound 4, half-maximal inhibitory concentration: 99 nM
Beside the measured number, compound 4's estimate is 2.0-fold (0.31 log units) above it; the measured number falls inside the stated range.
By their numbers in this assay, from the lowest: compounds 4 and 1 (each within the scatter of the next); then compound 3. At a limit, above all of these: compound 2.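

On the core of compound 1, this assay gives a 1.7-fold lower number from compound 1 to compound 4 (0.24 log units; within the scatter), so the 2-methyl-1H-indol-3-yl and 4-fluoro-1H-indol-3-yl groups on the double-bonded ring carbon cannot be told apart in this read-out. Among these compounds, this is the first direct comparison of these two groups, and it shows that a separation seen on a different core, an at least 4.0-fold lower number from compound 2 to compound 3 (0.61 log units; beyond the scatter), does not appear beyond the scatter when the group leaving is 4-fluoro-1H-indol-3-yl on the core of compound 1. Compound 2 stands at a limit and not at a number, so the earlier step has no definite size and cannot be set against the new one: the limit of > 5000 nM in this assay, at which 1 of the 4 values shown sits.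

The compounds shown leave open how this core would read with a plain 1H-indol-3-yl group, or with an indole carrying a chlorine or a longer chain such as ethyl, on the same ring carbon. They also leave open whether the two groups would stay this close if a carboxylic acid took the place of the hydroxamic acid.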